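The compounds below may be only part of what the source reports. "The series", "measured", "known", "first", "only" and "open" are said of these compounds alone.

Compound 1 `CN(C)CCCNc1nc(-c2ccc(NC(=O)Nc3ccccc3Cl)cc2)nc2c(Cl)c(Cl)sc12` gives 1560 nM in a functional assay on MDA-MB-231 cells (Homo sapiens) for cytotoxicity, read by MTT assay, with a stated time of 72 h; on this read-out lower numbers stand for stronger inhibition and higher numbers for weaker inhibition. Going by the values given here, compound 2 `Cc1ccc(NC(=O)Nc2ccc(-c3nc(NCCCN(C)C)c4sc(Cl)c(Cl)c4n3)cc2)cc1` gives 4980 nM in this assay and stands as the higher of the two numbers, the single measured step being a 3.2-fold higher number from compound 1 to compound 2 (0.50 log units; beyond the scatter). Compound 3 `CCN(CC)CCNc1nc(-c2ccc(NC(=O)Nc3ccc(C)cc3)cc2)nc2c(Cl)c(Cl)sc12` differs from compound 2 by diethylamino in place of (dimethylamino)methyl on a saturated chain carbon, two bonds along the chain from a nitrogen on an aromatic ring. Among the compounds with values here, the measured step changes only the aryl group on the amide-type nitrogen and does not bear on this change; no measured pair varies the amine chain. The step to compound 3 is therefore expected to stay within the scatter, a 1.0-fold higher number from compound 2 to compound 3 (0.00 log units; within the scatter). Compound 3 is estimated at 5000 nM, with a range from 2000 nM to 12500 nM.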

Compound 3, half-maximal inhibitory concentration: 2010 nM
The estimate for compound 3 lay 2.5-fold (0.40 log units) above the measured number; the range from low to high includes it.
By their numbers in this assay, from the lowest: compounds 1 and 3 (each within the scatter of the next); then compound 2.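

Varying the amine chain gives a 2.5-fold lower number from compound 2 to compound 3 (0.39 log units; beyond the scatter) in this assay when diethylamino replaces (dimethylamino)methyl, so this place on the chain is not silent. Going by these compounds alone, the one step reads as 3-(dimethylamino)propyl to 2-(diethylamino)ethyl, and it therefore joins a change of chain with a change of the groups on the amine. Nothing on hand explains the step.

Which of these two changes carries the step stays open. A 2-(dimethylamino)ethyl or 3-(diethylamino)propyl chain would separate them, and a morpholine at the chain end would test a ring amine here.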